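Dropping the Chloro: From Compound 3 to Compound 4

This account rests on a few compounds, and the source may have more. Where it says the series, first, only, none or still open, it means among the compounds named here.

Compound 3 `O=C(NO)c1ccc(NCc2nc(-c3ccc(Cl)cc3)nn2-c2ccccc2)cc1` gives 67.2% in an assay on Sf9 cells for inhibition of protein deacetylase HDAC6 (Homo sapiens), read by fluorescence, with a stated time of 40 min, tested at 100 nM (a higher number here means more inhibition at the concentration tested (going by the name of the read-out), a lower number less inhibition), the highest of the three measured numbers. Compound 1 `O=C(NO)c1ccc(NCc2nc(-c3ccco3)nn2-c2ccccc2)cc1` gives 59.9%. The step of a number 7.3 percentage points higher from compound 1 to compound 3 (within the scatter) stays within the scatter. Compound 2 `CNC(=O)c1ccc(NCc2nc(-c3ccccc3)nn2-c2ccccc2)cc1`, which carries a different group on the shared core, gives -3.6%, far below compound 3. Compound 4 `O=C(NO)c1ccc(NCc2nc(-c3ccccc3)nn2-c2ccccc2)cc1` differs from compound 3 by a single change: hydrogen in place of chloro on an aromatic carbon. Going by the values given here, the only measured step that bears on this change, the exchange of one aryl group for another between compound 1 and compound 3, stayed within the scatter, so removing the chloro is expected to move the number little. Compound 4 is therefore expected to give about 60%, between 42% and 76%. The expected step of a number 7.2 percentage points lower from compound 3 to compound 4 (within the scatter) should thus stay within the scatter.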

Compound 4, a percentage reported as inhibition, at one concentration (the size of the read-out at that concentration, not a potency): 72.6%
Compound 4: the middle estimate sits 12.6 percentage points below what was measured, and the stated range covers the measured number.
By their numbers in this assay, from the lowest: compound 2; then compounds 1, 3 and 4 (each within the scatter of the next, the first and the last beyond it).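

Taking off the chloro gives a number 5.4 percentage points higher from compound 3 to compound 4 (within the scatter) in this assay, so at this spot on the ring the chloro is not required for the inhibition seen. With the plain phenyl in place, a number 76.2 percentage points higher from compound 2 to compound 4 (beyond the scatter) ties the large difference to the hydroxy on the amide-type nitrogen. Swapping furan-2-yl for phenyl gives a number 12.7 percentage points higher from compound 1 to compound 4 (beyond the scatter), so this change of aryl group goes beyond the scatter, as the step to the 4-chlorophenyl did not.

Nothing given here explains these steps. From the compounds shown here alone, how a methoxy or an amine at the same ring position would compare remains open.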